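Hydroxyalkyl side chain: one added methyl

A few compounds are considered here, and "the series" means these few. Any claim that something is new, unique, unknown or untested is made for them only; others in the source may bear on it.

Measured in a functional assay on CH1 cells (Homo sapiens) for inhibition, read by sulforhodamine B assay, with a stated time of 96 h; a higher number here means a weaker inhibitor of growth, a lower number a stronger inhibitor of growth:
- compound 1 `CC[C@@H](Nc1nc(NCc2ccccn2)c2ncn(C(C)C)c2n1)C(O)C(C)(C)C`: 34000 nM
- compound 2 `CC[C@H](Nc1nc(NCc2ccccn2)c2ncn(C(C)C)c2n1)C(C)O`: 21000 nM

Compound 2 stands at 21000 nM, within the scatter of compound 1, so the two cannot be ranked. Compound 3 `CC[C@H](Nc1nc(NCc2ccccn2)c2ncn(C(C)C)c2n1)C(C)(C)O` keeps the core of compound 2 and alters only the side chain: methyl in place of hydrogen on a saturated chain carbon bound to an oxygen on a saturated carbon and two saturated chain carbons. This turns 1-hydroxyethyl into 1-hydroxy-1-methylethyl.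

Among the measured compounds shown here, the only measured step bearing on this chain is a 1.6-fold lower number from compound 1 to compound 2 (0.21 log units; within the scatter). For the measured compounds named here, with that step as the sole guide, no change beyond the scatter is expected in this assay, and neither direction is favoured. The step expected is a 1.1-fold lower number from compound 2 to compound 3 (0.02 log units; within the scatter). The estimate for compound 3 is 20000 nM, with an expected range of 9000 nM to 45000 nM.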

Compound 3, concentration for 50% growth inhibition: 42000 nM
Compound 3: middle estimate off by 2.1-fold (0.32 log units), on the low side; measured number inside the range.
By their numbers in this assay, from the lowest: compounds 2, 1 and 3 (each within the scatter of the next).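

In this assay, methyl in place of hydrogen on the saturated chain carbon bound to the oxygen, turning 1-hydroxyethyl into 1-hydroxy-1-methylethyl, gives a 2.0-fold higher number from compound 2 to compound 3 (0.30 log units; within the scatter), so the series now has a direct reading at this carbon and the added methyl brings no change that can be told from the scatter. Setting 1-(1-hydroxy-1-methylethyl)propyl in place of 1-ethyl-2-hydroxy-3,3-dimethylbutyl gives a 1.2-fold higher number from compound 1 to compound 3 (0.09 log units; within the scatter), so these side chains still cannot be ranked in this assay. No measurement at hand bears on the reason for these numbers.

Open, on these data alone, is whether the hydroxyl itself matters at this carbon, which an amine or a methyl ether in its place would address. Also open, as far as these compounds go, is whether a longer chain, such as ethyl in place of the added methyl, would move the number beyond the scatter.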